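Methyl on the benzamide ring of a pyrazolopyrimidinone

This account rests on a few compounds, and the source may have more. Where it says the series, first, only, none or still open, it means among the compounds named here.

Measured so far:
compound 1, `O=C(Nn1c(-c2ccccc2)nc2c(-c3ccc(Cl)cc3)n[nH]c2c1=O)c1ccccc1`, 20600 nM in a functional assay on HT-29 cells (Homo sapiens) for inhibition, read by MTT assay, with a stated time of 2 days; a higher number here means a weaker inhibitor of growth, a lower number a stronger inhibitor of growth
compound 2, `CCCCCc1nc2c(-c3ccc(Cl)cc3)n[nH]c2c(=O)n1NC(=O)c1ccccc1`, 2260 nM in this assay

Compound 2 stands at the lower of the two numbers recorded so far; its nearest neighbour is compound 1, and the step of a 9.1-fold lower number from compound 1 to compound 2 (0.96 log units; beyond the scatter) lies beyond the scatter. Compound 3, `CCCCCc1nc2c(-c3ccc(Cl)cc3)n[nH]c2c(=O)n1NC(=O)c1cccc(C)c1`, has not been measured. It differs from compound 2 in one place: methyl in place of hydrogen on an aromatic carbon. Within the data shown here, the only measured step, from compound 1 to compound 2, concerns a pentyl in place of a phenyl on an aromatic carbon of the shared core, not the benzamide ring, so no measured step bears directly on the change to compound 3. With nothing to support a shift in either direction, the step of a 1.0-fold lower number from compound 2 to compound 3 (0.01 log units; within the scatter) is expected to stay within the scatter. Compound 3 is therefore estimated at 2200 nM in this assay, with a range from 700 nM to 7000 nM.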

Compound 3, concentration for 50% growth inhibition: 5370 nM
Compound 3: the middle estimate sits 2.4-fold (0.39 log units) below what was measured; the measured number falls inside the stated range.
By their numbers in this assay, from the lowest: compound 2; then compound 3; then compound 1.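

In this assay the benzamide ring responds to the smallest of additions: a methyl on an aromatic carbon, meta to a large group, gives a step beyond the scatter (a 2.4-fold higher number from compound 2 to compound 3 (0.38 log units; beyond the scatter)). Among these compounds, this is the first measured change on this ring, since the earlier step concerned only the other aromatic carbon of the shared core, and it runs towards a weaker inhibitor of growth. Nothing available accounts for this shift.

On these data alone, whether a chlorine, a methoxy group or an amine at this same carbon would move the number in the same direction remains open. So does whether a methyl elsewhere on this ring, or the same methyl on compound 1 with its phenyl group, would give a step of similar size.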